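Swapping the chain amine on compound 3

The compounds below may be only part of what the source reports. "The series", "measured", "known", "first", "only" and "open" are said of these compounds alone.

Measured so far:
compound 1 `CCN1CCN(c2nc(NCc3ccc(F)cc3)nc3c2ncn3CCCN2CCCC2)CC1` 40 nM
compound 2 `COc1ccc(CNc2nc(N3CCN(C4CCCC4)CC3)c3ncn(CCCN4CCCC4)c3n2)cc1` 240 nM
compound 3 `CCN1CCN(CCCn2cnc3c(N4CCN(CC)CC4)nc(NCc4ccc(OC)cc4)nc32)CC1` 200 nM

These three compounds were tested in an assay on HEK293 cells for antagonist activity at Toll-like receptor 9 (Homo sapiens), read by spectrophotometry; on this read-out lower numbers stand for stronger inhibition and higher numbers for weaker inhibition. Compound 3 stands second highest of the three numbers. Its nearest neighbour is compound 2, whose number differs from it by an amount that lies within the usual scatter, so the two cannot be told apart. Compound 1 lies furthest away, with a number beyond the scatter lower than that of compound 3.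

Compound 4 `CCN1CCN(c2nc(NCc3ccc(OC)cc3)nc3c2ncn3CCCN2CCCC2)CC1` has not yet been measured. It differs from compound 3 in one place: pyrrolidin-1-yl in place of 4-ethylpiperazin-1-yl on a saturated chain carbon, three bonds along the chain from an aromatic nitrogen. With this change, compound 4 comes to carry the same pyrrolidin-1-yl group on its saturated chain that compound 1 carries, while keeping the rest of compound 3 unchanged.

Within the data shown here, no measured pair shows this exact change, so the expectation rests on the closeness of compound 4 to compound 1, whose number in this assay is 40 nM. A step toward a lower number is expected, of moderate size and beyond the scatter, a 2.5-fold lower number from compound 3 to compound 4 (0.40 log units; beyond the scatter). Compound 4 is estimated at 80 nM, within a range from 30 nM to 250 nM.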

Compound 4, half-maximal inhibitory concentration: 80 nM
For compound 4 middle estimate and measured number coincide at the digits printed; the measured number falls inside the stated range.
By their numbers in this assay, from the lowest: compounds 1 and 4 (each within the scatter of the next); then compounds 3 and 2 (each within the scatter of the next).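

In this assay, among these compounds, the step of a 2.5-fold lower number from compound 3 to compound 4 (0.40 log units; beyond the scatter) is the first one-place reading at this position: 3-(pyrrolidin-1-yl)propyl in place of 3-(4-ethylpiperazin-1-yl)propyl, a swap of a six-membered ring with two nitrogens for a five-membered ring with one, moves the number beyond the scatter. Among the compounds shown here, compound 4 also gives the first reading at the amine nitrogen in a ring, where ethyl in place of cyclopentyl gives a 3.0-fold lower number from compound 2 to compound 4 (0.48 log units; beyond the scatter), and the first at the aromatic carbon, where methoxy in place of fluoro gives a 2.0-fold higher number from compound 1 to compound 4 (0.30 log units; within the scatter), so these last two compounds cannot be told apart. Nothing measured here accounts for any of these steps.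

Still open, from the compounds shown here alone, is whether other amines on the same chain, such as piperidin-1-yl or morpholin-4-yl, or a longer butyl chain ending in pyrrolidin-1-yl, would match the pyrrolidin-1-yl result. Also open, going by these compounds, is whether a methyl group on the amine nitrogen in the ring, or a chloro group on the aromatic carbon, would shift the number.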